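A few compounds are considered here, and "the series" means these few. Any claim that something is new, unique, unknown or untested is made for them only; others in the source may bear on it.

Three compounds built on one shared core have been examined in an assay for inhibition of hexokinase-2 (Homo sapiens), read by coupled enzyme assay, with a stated time of 10 min, in the presence of a further agent that is not named here; a higher number here means a weaker inhibitor, a lower number a stronger inhibitor. Compound 1 `C=C1CC[C@H]2[C@@](C)(CCC(=O)N[C@@]2(C)COC(=O)c2ccccc2)[C@@H]1/C=C/C1=CCOC1=O` gives > 50000 nM in this assay, which is a limit of the assay and not a number. Compound 2 `C=C1CC[C@H]2[C@@](C)(CCC(=O)N[C@@]2(C)COC(=O)c2ccc([N+](=O)[O-])cc2)[C@@H]1/C=C/C1=CCOC1=O` gives > 50000 nM in this assay, again a limit. Compound 3 `C=C1CC[C@H]2[C@@](C)(CCC(=O)N[C@@]2(C)COC(=O)[C@H](N)CC(C)C)[C@@H]1/C=C/C1=CCOC1=O` gives > 50000 nM in this assay, also a limit. Compound 3 therefore stands exactly where the other two stand, at the limit of > 50000 nM in this assay, at which 3 of the 3 values shown sit, and nothing separates the three.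

The step from compound 1 to compound 2 is a step that the two limits leave unreadable from compound 1 to compound 2, the step from compound 1 to compound 3 is a step that the two limits leave unreadable from compound 1 to compound 3, and the step from compound 2 to compound 3 is a step that the two limits leave unreadable from compound 2 to compound 3. Each of these changes sits on the carbonyl carbon or its aromatic substituent, yet none can be read.

Compound 4 `C=C1CC[C@H]2[C@@](C)(CCC(=O)N[C@@]2(C)COC(=O)CCCC[C@@H]2CCSS2)[C@@H]1/C=C/C1=CCOC1=O` differs from compound 3 by a group of 9 heavy atoms (7 carbon, 2 sulfur; one five-membered non-aromatic ring with 2 hetero atoms) in place of a group of 6 heavy atoms (5 carbon, 1 nitrogen; no ring), on a carbonyl carbon. The three measured steps all run between values at the limit of > 50000 nM in this assay, at which 3 of the 3 values shown sit, so none bears on this change with a readable size. With every value seen so far at a limit, the expectation is that compound 4 will also return only a limit in this assay. The expected step is a step that the limit leaves unreadable from compound 3 to compound 4. Compound 4 is estimated at 80000 nM, within a range from 20000 nM to 400000 nM.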

Compound 4, half-maximal inhibitory concentration: 9360 nM
Compound 4: the middle estimate sits 8.5-fold (0.93 log units) above what was measured; measured number outside the range, below it.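

Changing the group on the carbonyl carbon can bring this series off the assay limit: in this assay, the group with one five-membered non-aromatic ring holding 2 hetero atoms, both sulfur, gives an at least 5.3-fold lower number from compound 3 to compound 4 (0.72 log units; beyond the scatter), and equally an at least 5.3-fold lower number from compound 2 to compound 4 (0.72 log units; beyond the scatter) and an at least 5.3-fold lower number from compound 1 to compound 4 (0.72 log units; beyond the scatter). Within the data shown here, this position therefore responds to what it carries, something the earlier compounds could not show, since the steps among their phenyl, 4-nitrophenyl and 1-amino-3-methylbutyl groups cannot be read: the limit of > 50000 nM in this assay, at which 3 of the 4 values shown sit. Each of the three new sizes is a minimum and not a full measure, as each starting compound has a limit and not a number.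

As far as these compounds go, what remains open is whether the sulfur-containing ring, the carbon chain that carries it, or simply the larger group of carbon and sulfur accounts for the step. A plain longer carbon chain without the ring, or the same chain ending in a carboxylic acid, would help separate these possibilities, and nothing shown says how far the number can fall at this position.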